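Removing One Methyl in Two Related Compounds

The source may report more compounds than this note shows. Statements on the series, on what has been measured and on what is new or still open speak of the compounds shown alone.

Compound 1 `COc1ccc(C(=O)NNC(=O)/C=C/c2ccc(O)c(O)c2)cc1` and compound 2 `O=C(/C=C/c1ccc(O)c(O)c1)NNC(=O)c1ccc(O)cc1` differ by a single change, (hydrogen in place of methyl on an oxygen on an aromatic ring), and both were tested in a functional assay on MCF7 cells (Homo sapiens) for antiproliferative activity, read by MTT assay, with a stated time of 24 h; a higher number here means a weaker inhibitor, a lower number a stronger inhibitor. Compound 1 gives 4860 nM, while compound 2 gives 6050 nM, a step of a 1.2-fold higher number from compound 1 to compound 2 (0.10 log units; within the scatter). Compound 3 `COc1ccc(C(=O)NNC(=O)/C=C/c2cc(OC)c(O)c(OC)c2)cc1` has a different core; how that core differs from the core of compound 1 is not broken down here. In this assay compound 3 gives 7170 nM, and this number lies within the scatter of both compound 1 and compound 2. Compound 4 `COc1cc(/C=C/C(=O)NNC(=O)c2ccc(O)cc2)cc(OC)c1O` carries the same change relative to compound 3, namely (hydrogen in place of methyl on an oxygen on an aromatic ring), at a place described in identical words. Because the earlier step of a 1.2-fold higher number from compound 1 to compound 2 (0.10 log units; within the scatter) fell within the scatter, a similarly small shift is expected; for compound 4 the expected step is a 1.2-fold higher number from compound 3 to compound 4 (0.07 log units; within the scatter). Compound 4 is estimated to give 8500 nM in this assay, likely between 4000 nM and 18000 nM.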

Compound 4, half-maximal inhibitory concentration: 9320 nM
Compound 4: the middle estimate sits 1.1-fold (0.04 log units) below what was measured; low and high end bracket the measured number.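

Replacing methoxy with hydroxy in this assay gives a step of a 1.3-fold higher number from compound 3 to compound 4 (0.11 log units; within the scatter), so compound 4 stays close to compound 3. On the two cores shown, the change from 4-methoxyphenyl to 4-hydroxyphenyl behaves alike: the same change on two cores in this assay, a 1.2-fold higher number (0.10 log units; within the scatter) from compound 1 to compound 2 and a 1.3-fold higher number (0.11 log units; within the scatter) from compound 3 to compound 4, 1.0-fold (0.02 log units) apart, within the scatter of two such steps. Both steps are small, so this is agreement between two near-zero changes; it does not show that the change would stay this small on a further core, nor does it tell what the hydroxy or methoxy group contributes to activity.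

The compounds shown leave open whether a different group in place of the hydroxy, such as an amine, a carboxylic acid or a longer ethoxy chain, would move the number beyond the scatter.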